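The source may hold more compounds than are shown below. What is called first, only, known or untested is meant among the compounds shown, and "the series" means these compounds.

Of the compounds shown here, two sharing one core have been measured. Compound 1 `Cc1ccc(CN2CCC(CCN(Cc3ccc(-c4ccc(F)cc4)cc3)C(=O)NC(C)(C)CO)CC2)cc1` gives 7.39 in an in vitro functional assay on HEK293 cells for antagonist activity at melanin-concentrating hormone receptor 1 (Homo sapiens), read by GTPgammaS binding, with a stated time of 45 min; a lower number here means a less potent compound, a higher number a more potent compound, by a factor of ten per unit of this negative logarithm. Within the data shown here, compound 2 `Cc1ccc(CN2CCC(CCN(Cc3ccc(-c4cccc(C#N)c4)cc3)C(=O)NC(C)(C)CO)CC2)cc1` gives 7.08 in this assay, and the step of a number 0.31 log units lower from compound 1 to compound 2 (beyond the scatter) leaves compound 2 as the lower of the two numbers; its only neighbour, compound 1, stands higher by an amount beyond the scatter. Compound 3 `Cc1ccc(CN2CCC(CCN(Cc3ccc(-c4ccccc4)cc3)C(=O)NC(C)(C)CO)CC2)cc1` has not yet been measured. Its difference from compound 2 is hydrogen in place of cyano on an aromatic carbon: the cyano group leaves the six-membered aromatic ring of carbon only and a hydrogen takes its place, so that 3-cyanophenyl becomes phenyl. Among the measured compounds shown here, only one measured step touches this ring, a number 0.31 log units lower from compound 1 to compound 2 (beyond the scatter), and it is modest. Compound 3 is therefore expected to move in this assay by a number 0.17 log units higher from compound 2 to compound 3 (within the scatter), a small rise at most. For compound 3 the estimate is 7.25, with a range from 6.85 to 7.65.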

Compound 3, negative logarithm of the antagonist equilibrium constant: 6.2
Estimate against measurement, compound 3: 1.05 log units above, and the stated range ends above it.
By their numbers in this assay, from the lowest: compound 3; then compound 2; then compound 1.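

In this assay, the bare phenyl compound falls short of both substituted compounds, with a number 0.88 log units lower from compound 2 to compound 3 (beyond the scatter) on the loss of the cyano group and a number 1.19 log units lower from compound 1 to compound 3 (beyond the scatter) on the loss of the fluoro group. Having a substituent on this ring therefore counts for more here than the choice between the two substituents, since both of these steps are larger than a number 0.31 log units lower from compound 1 to compound 2 (beyond the scatter). Nothing measured here explains why a hydrogen at these places gives so much lower a number.

Because the 3-cyanophenyl and 4-fluorophenyl groups differ both in the substituent and in where it sits on the ring, the compounds shown cannot separate those two influences. From the compounds shown here alone, whether chloro, methoxy or an amine on this ring would match or exceed compound 1 also stays open.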